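The compounds below may be only part of what the source reports. "The series", "measured", "known", "first", "only" and "open" are said of these compounds alone.

Compound 1 `CCN1C(=O)/C(=C/c2ccc(OC)cc2)SC1=S` is the reference. In an assay for inhibition of LL-diaminopimelate aminotransferase, chloroplastic (Arabidopsis thaliana) (a lower number here means a stronger inhibitor, a higher number a weaker inhibitor), compound 1 gives only a limit, > 200000 nM, which is the limit of > 200000 nM in this assay, at which 1 of the 3 values shown sits. Compound 3 `CCN1C(=O)/C(=C/c2ccc(Cl)cc2)SC1=S` gives 200000 nM in this assay. Compound 2 `N=C1NC(=O)/C(=C/c2ccc(-c3ccc([N+](=O)[O-])cc3Br)o2)S1` gives 85000 nM in this assay. Going by the values given here, the single measured step, a number no higher from compound 1 to compound 3 (the limit leaves the size open), concerns a change on an aromatic carbon and leaves its size open, since compound 1 stands only as a limit. Compound 4 `COc1ccc(/C=C2\SC(=S)N(N)C2=O)cc1` differs from compound 1 by amino in place of ethyl on an amide-type nitrogen in a ring. Among the compounds with values here, no measured step touches the amide-type nitrogen in the ring, so the measured steps give no size to carry over, and no step beyond the scatter is expected in this assay. Compound 4 is therefore estimated at 200000 nM, with a range of 50000 nM to 800000 nM. The step expected is a number no higher from compound 1 to compound 4 (the limit leaves the size open).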

Compound 4, half-maximal inhibitory concentration: 155000 nM
Beside the measured number, compound 4's estimate is 1.3-fold (0.11 log units) above it, within the range that was stated.
By their numbers in this assay, from the lowest: compounds 2, 4 and 3 (each within the scatter of the next, the first and the last beyond it).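

Amino in place of ethyl on the amide-type nitrogen in the ring gives an at least 1.2-fold lower number from compound 1 to compound 4 (0.11 log units; that floor lies within the scatter) in this assay. This is the first step shown at this position, and as a floor it does not establish that the change strengthens inhibition. The step has no upper bound because compound 1 stands only as a limit of the assay: the limit of > 200000 nM in this assay, at which 1 of the 4 values shown sits.

The compounds shown leave open the true size of this step. They also leave open how a longer chain, a hydroxyethyl group or a carboxylic acid on that nitrogen would read in this assay.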